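The source may report more compounds than this note shows. Statements on the series, on what has been measured and on what is new or still open speak of the compounds shown alone.

Measured so far:
Compound 1, `COc1ccc(-c2cc(=O)c3ccc(F)cc3o2)cc1`: 40%
Compound 2, `COc1ccc(-c2cc(=O)c3ccc(C)cc3o2)cc1`: 40%
Compound 3, `Cc1ccc2c(c1)OC(c1ccc(F)cc1)CC2=O`: "not active" (no number reported)

All three were tested in an in vitro assay on BTI-TN-5B1-4 cells for inhibition of Amine oxidase [flavin-containing] A (Homo sapiens), tested at 100 uM; a higher number here means more inhibition at the concentration tested (going by the name of the read-out), a lower number less inhibition. Compound 1 and compound 2 share one core, while compound 3 is built on a different core; the difference between the two cores is not broken down here. The change from compound 2 to compound 1 is fluoro in place of methyl on an aromatic carbon and gave no change at the digits printed from compound 2 to compound 1 (within the scatter). Compound 4, `O=C1CC(c2ccc(F)cc2)Oc2cc(F)ccc21`, has not yet been measured. It stands to compound 3 as compound 1 stands to compound 2, through (fluoro in place of methyl on an aromatic carbon), the same change at the same kind of place. For compound 3 no number was reported in this assay, only that it was not active. I therefore expect the step from compound 3 to compound 4 to be small, like the earlier step, because no change at the digits printed from compound 2 to compound 1 (within the scatter) stayed within the scatter. Compound 4 is expected to give about 10% in this assay, and most likely between 0% and 30%, with a real chance that it is again reported only as not active.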

Compound 4, a percentage reported as inhibition, at one concentration (the size of the read-out at that concentration, not a potency): "not active" (no number reported)
For compound 4 the study gives words and no number, and the estimate cannot be compared.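

Compound 3 and compound 4 are both reported in this assay only as not active, with no number, so no step can be read between them. No measurement shown here offers an explanation for this result. The compounds shown leave open whether fluoro in place of methyl changes inhibition at all on the core of compound 3.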